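Adding One Isopropyl Group to a Phenyl Ester

The source may hold more compounds than are shown below. What is called first, only, known or untested is meant among the compounds shown, and "the series" means these compounds.

Values in a functional assay on MDA-MB-231 cells (Homo sapiens) for inhibition, read by WST assay, with a stated time of 48 h (a higher number here means a weaker inhibitor, a lower number a stronger inhibitor), are as follows

- Compound 1 `CC/C=C\C/C=C\C/C=C\C/C=C\C/C=C\C/C=C\CCC(=O)Oc1ccc(C(C)C)cc1C(C)C` gives 7300 nM
- Compound 2 `CC/C=C\C/C=C\C/C=C\C/C=C\C/C=C\C/C=C\CCC(=O)Nc1ccccc1C(C)C` gives 6500 nM
- Compound 3 `CC/C=C\C/C=C\C/C=C\C/C=C\C/C=C\C/C=C\CCC(=O)Oc1ccccc1` gives > 25000 nM

For compound 3 the > 25000 nM is a limit of the assay and not a number. Compound 4 `CC/C=C\C/C=C\C/C=C\C/C=C\C/C=C\C/C=C\CCC(=O)Oc1ccccc1C(C)C` differs from compound 3 by isopropyl in place of hydrogen on an aromatic carbon, ortho to a large group (isopropyl in place of hydrogen on an aromatic carbon). Within the data shown here, two measured steps bear on this change, and both run in the opposite direction. Loss of the isopropyl groups gave an at least 3.4-fold higher number from compound 1 to compound 3 (0.53 log units; beyond the scatter) and replacing the amide part with phenoxy gave an at least 3.8-fold higher number from compound 2 to compound 3 (0.58 log units; beyond the scatter) as its counterpart. Both are minimum sizes. Reversing them, a fall beyond the scatter is expected, so the estimate is an at least 3.3-fold lower number from compound 3 to compound 4 (0.52 log units; beyond the scatter) in this assay as expected. Compound 4 is expected at 7500 nM within an estimated range of 3500 nM to 18000 nM in this reading.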

Compound 4, half-maximal inhibitory concentration: 8200 nM
The estimate for compound 4 lay 1.1-fold (0.04 log units) below the measured number; measured number inside the range.
By their numbers in this assay, from the lowest: compounds 2, 1 and 4 (each within the scatter of the next). At a limit, above all of these: compound 3.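

In this assay, a single isopropyl group on the phenyl ester gives an at least 3.0-fold lower number from compound 3 to compound 4 (0.48 log units; beyond the scatter), and this is only a minimum size, as compound 3 stands at a limit of the assay and not at a number: the limit of > 25000 nM in this assay, at which 1 of the 4 values shown sits. The further isopropyl group of compound 1 is not needed, with a gap inside the scatter: a 1.1-fold higher number from compound 1 to compound 4 (0.05 log units; within the scatter). The ester and the amide also cannot be told apart when each carries the isopropyl group: a 1.3-fold higher number from compound 2 to compound 4 (0.10 log units; within the scatter).

From the compounds shown here alone, the full size of the step from hydrogen to isopropyl remains open. So does whether a methyl group or an amine at this place would do the same.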